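Chain homologues in the curcumin-like cytotoxicity series

This account rests on a few compounds, and the source may have more. Where it says the series, first, only, none or still open, it means among the compounds named here.

Compound 1 `COc1cc(/C=C/C(=O)/C=C(/C=C/c2ccc(O)c(OC)c2)NCCCO)ccc1O` and compound 2 `COCCNC(=C\C(=O)/C=C/c1ccc(O)cc1)/C=C/c1ccc(O)cc1` share a core with two enone arms joined through an enamine nitrogen; they differ in the arm substituents and in the chain on the nitrogen. In a functional assay on HT-29 cells (Homo sapiens) for cytotoxicity, read by MTT assay, with a stated time of 48 h (on this read-out higher numbers stand for weaker inhibition and lower numbers for stronger inhibition), compound 1 reaches only the limit > 100000 nM, not a number. In this assay, among the measured compounds shown here, compound 2 gives 57400 nM, the only real number in the set. The other value, that of compound 1, is a limit (the limit of > 100000 nM in this assay, at which 1 of the 2 values shown sits).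

Compound 3 `COCCCNC(=C\C(=O)/C=C/c1ccc(O)cc1)/C=C/c1ccc(O)cc1` is the next homologue of compound 2: methoxymethyl in place of methoxy on a saturated chain carbon, two bonds along the chain from an amine nitrogen, on a saturated chain carbon, two bonds along the chain from an amine nitrogen. For the measured compounds named here, no measured step of this kind is available, so the expectation rests on compound 2 alone and on the small size of the change; the step from compound 2 to compound 3 is expected to stay within the scatter, a 1.0-fold lower number from compound 2 to compound 3 (0.02 log units; within the scatter). Compound 3 is accordingly expected to give about 55000 nM in this assay, between 25000 nM and 100000 nM, with some chance that only a limit is reported.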

Compound 3, half-maximal inhibitory concentration: 51900 nM
The estimate for compound 3 lay 1.1-fold (0.03 log units) above the measured number; low and high end bracket the measured number.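

In this assay, among the compounds shown here, exchanging (2-methoxyethyl)amino for (3-methoxypropyl)amino gives a 1.1-fold lower number from compound 2 to compound 3 (0.04 log units; within the scatter), so this is the first step that can be read, and at this position the added chain carbon produces no change beyond the scatter. One step on a single pair supports no trend with chain length. Compound 1 remains a limit and differs from the other compounds in more than one place, so no step to it can be read: the limit of > 100000 nM in this assay, at which 1 of the 3 values shown sits.

Going by these compounds, whether an amine or a carboxylic acid in place of the methoxy, or a chain longer than 3-methoxypropyl, would move the number beyond the scatter remains open. Also open, on these data alone, is whether the same chain change would read alike with the arm substituents of compound 1.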